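This account rests on a few compounds, and the source may have more. Where it says the series, first, only, none or still open, it means among the compounds named here.

Measured so far:
compound 1 `COc1ccc(-c2ccc3c(NCCCNCc4cccc(OC)c4O)ccnc3c2)cc1` — 237 10^-6 cm/s
compound 2 `FC(F)(F)c1ccc(-c2ccc3c(NCCCNCc4ccco4)ccnc3c2)cc1` — 237 10^-6 cm/s
compound 3 `Fc1ccc(Cc2ccc3c(NCCCNCc4ccco4)ccnc3c2)cc1` — 23 10^-6 cm/s

In an ADME assay for permeability, using PAMPA, with a stated time of 30 min, at pH 7.4 (a higher number here means that the compound crosses the layer faster, a lower number that the compound crosses the layer more slowly), compound 1 gives 237 10^-6 cm/s, the same at the digits printed as compound 2, and together these two are the highest of the three numbers. Compound 3 stands furthest from compound 1, as shown by a 10-fold lower number from compound 2 to compound 3 (1.01 log units; beyond the scatter).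

Compound 4 `COc1cccc(CNCCCNc2ccnc3cc(Oc4ccc(F)cc4)ccc23)c1O` is not yet measured. Relative to compound 1 the change is 4-fluorophenoxy in place of 4-methoxyphenyl on an aromatic carbon. For the measured compounds named here, the one measured step, from compound 2 to compound 3, bears on this: there too an aryl group bound directly to the core was exchanged for a group in which the aromatic ring is carried on a bridge, and the number fell by a 10-fold lower number from compound 2 to compound 3 (1.01 log units; beyond the scatter). Compound 4 carries a comparable exchange, though the group entering here differs from 4-fluorobenzyl, so the size of the effect is uncertain. A lower number is therefore expected, of roughly a 3.0-fold lower number from compound 1 to compound 4 (0.47 log units; beyond the scatter), with the full size of the measured step as the lower end of what is plausible.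

Compound 4 is estimated at 80 10^-6 cm/s, within 25 10^-6 cm/s to 200 10^-6 cm/s.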

Compound 4, apparent permeability: 317 10^-6 cm/s
For compound 4 the middle estimate is 4.0-fold (0.60 log units) below the measured one; measured number outside the range, above it.
By their numbers in this assay, from the lowest: compound 3; then compounds 1, 2 and 4 (each within the scatter of the next).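

In this assay, 4-fluorophenoxy in place of 4-methoxyphenyl gives a 1.3-fold higher number from compound 1 to compound 4 (0.13 log units; within the scatter), so at this position on the core of compound 1 an aromatic ring carried on an oxygen leaves the number within the scatter of the directly bound aryl group. Compound 4 therefore goes against reading a 10-fold lower number from compound 2 to compound 3 (1.01 log units; beyond the scatter) as a general result of moving the ring away from the core: that large step belongs to 4-fluorobenzyl in place of 4-(trifluoromethyl)phenyl, in a different compound pair, and does not reappear with this exchange. No measurement at hand accounts for the contrast between the two exchanges.

The compounds shown leave open whether 4-fluorobenzyl on the core of compound 1 would bring a step like the one seen for compound 3, or whether the size of that step depends on the rest of the molecule. Also open, on these data alone, is how this assay responds at this position to a carboxylic acid or an amine, or to a longer chain between the aromatic ring and the core.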